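From 4-fluorophenoxy to 3-chlorophenoxy

A few compounds are considered here, and "the series" means these few. Any claim that something is new, unique, unknown or untested is made for them only; others in the source may bear on it.

Going by the values given here, in a functional assay on A549 cells (Homo sapiens) for antiproliferative activity, read by MTT assay, with a stated time of 72 h (on this read-out lower numbers stand for stronger inhibition and higher numbers for weaker inhibition), compound 3 `NC1=NC2(CCOCC2)N(OCCCOc2ccc(F)cc2)C(N)=N1` gives 1060 nM, the highest of the three numbers so far. Compound 2 `NC1=NC2(CCOCC2)N(OCCCOc2ccc(Cl)cc2)C(N)=N1` gives 360 nM, and compound 1 `CC(C)(C)c1ccc(OCCCON2C(N)=NC(N)=NC23CCSCC3)cc1` gives 1 nM. Among the compounds with values here, compound 1 differs from compound 3 in more than one place, so it offers no single step to read here.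

Compound 4 `NC1=NC2(CCOCC2)N(OCCCOc2cccc(Cl)c2)C(N)=N1` departs from compound 3 by 3-chlorophenyl in place of 4-fluorophenyl on an oxygen on a saturated carbon. Within the data shown here, one measured step bears on this change, a 2.9-fold higher number from compound 2 to compound 3 (0.47 log units; beyond the scatter), which is modest and beyond the scatter. Among the measured compounds shown here, compound 4 reverses that exchange of halogens, but no measured compound carries 3-chlorophenyl, so the data do not show how the new chloro placement counts. A modest step to a lower number is therefore expected in this assay, with wide uncertainty. The expected step is a 2.2-fold lower number from compound 3 to compound 4 (0.34 log units; beyond the scatter). For compound 4 the estimated value is 480 nM, with an expected range of 170 nM to 1300 nM.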

Compound 4, half-maximal inhibitory concentration: 150 nM
Beside the measured number, compound 4's estimate is 3.2-fold (0.51 log units) above it; the measured number lies below the stated range.
By their numbers in this assay, from the lowest: compound 1; then compound 4; then compound 2; then compound 3.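

With the chloro kept, the shift from 4-chlorophenyl to 3-chlorophenyl gives a 2.4-fold lower number from compound 2 to compound 4 (0.38 log units; beyond the scatter) in this assay, so placement on this ring counts as well as the identity of the halogen. The whole change from 4-fluorophenyl to 3-chlorophenyl, a 7.1-fold lower number from compound 3 to compound 4 (0.85 log units; beyond the scatter), therefore divides into that shift and the exchange of halogens, which reads in the opposite direction as a 2.9-fold higher number from compound 2 to compound 3 (0.47 log units; beyond the scatter). No measurement here accounts for either part.

From the compounds shown here alone, whether a nitrile or a methoxy group in place of the chloro of compound 4 would give a lower or a higher number remains open. Also open, going by these compounds, is how a longer chain between the two oxygens would read, and compound 1 differs from compound 4 in more than one place, so it settles neither question.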